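Series notes: aryl to saturated ring swap at compound 2

A few compounds are considered here, and "the series" means these few. Any claim that something is new, unique, unknown or untested is made for them only; others in the source may bear on it.

The three measured compounds share one core. Compound 1 `CNc1nc2c(-c3ccnc(OC)c3)cnn2cc1C` gives 1300 nM in an assay on isolated protein for inhibition of activin receptor type-2A (Homo sapiens), read by 33P incorporation, with a stated time of 20 min, in the presence of a further agent that is not named here; a lower number here means a stronger inhibitor, a higher number a weaker inhibitor. Compound 3 `CNc1nc2c(-c3ccnc(OC)c3)cnn2cc1C1CC1` gives 630 nM. Compound 2 `COc1cc(-c2cnn3cc(OC)c(-c4cc(C)no4)nc23)ccn1` gives 3000 nM, the highest of the three numbers; its nearest neighbour is compound 1 and the furthest is compound 3, both beyond the scatter.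

Going by the values given here, the one measured step, a 2.1-fold lower number from compound 1 to compound 3 (0.31 log units; beyond the scatter), concerns cyclopropyl in place of methyl on an aromatic carbon and is modest. It sits on a different carbon of the core from the change considered here.

Compound 4 `COc1cc(-c2cnn3cc(OC)c([C@H]4COC(C)(C)C4)nc23)ccn1` differs from compound 2 by a group of 7 heavy atoms (6 carbon, 1 oxygen; one five-membered non-aromatic ring with 1 hetero atom) in place of a group of 6 heavy atoms (4 carbon, 1 nitrogen, 1 oxygen; one five-membered aromatic ring with 2 hetero atoms), on an aromatic carbon. Among the compounds with values here, no measured pair addresses a swap of an aromatic five-membered ring for a non-aromatic one at this position, so the only guidance is that the one substituent change recorded moved the number by a modest amount. The expectation is therefore a step of no more than modest size in either direction, a 1.5-fold lower number from compound 2 to compound 4 (0.18 log units; within the scatter), with wide uncertainty. Compound 4 is estimated at 2000 nM in this assay, within a range of 500 nM to 8000 nM.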

Compound 4, half-maximal inhibitory concentration: 4100 nM
Compound 4: the middle estimate sits 2.1-fold (0.31 log units) below what was measured; the measured number falls inside the stated range.
By their numbers in this assay, from the lowest: compound 3; then compound 1; then compounds 2 and 4 (each within the scatter of the next).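

In this assay, the step at this position, a 1.4-fold higher number from compound 2 to compound 4 (0.14 log units; within the scatter), lies within the scatter, so this pair does not separate the 3-methyl-1,2-oxazol-5-yl group from the entering non-aromatic ring. Going by these compounds alone, this is the first reading at this aromatic carbon, and it shows that a five-membered aromatic ring with 2 hetero atoms can give way to a five-membered non-aromatic ring with 1 hetero atom and 1 defined stereocentre without a step beyond the scatter. No supporting measurement bears on this result, and the reading stands without an explanation.

The compounds shown leave open whether a morpholine, a primary amine or a carboxylic acid on this carbon would move the number beyond the scatter, and whether the mirror-image form of the entering ring would read the same. Within the data shown here, they also leave open how this position relates to the change of cyclopropyl in place of methyl, seen in a 2.1-fold lower number from compound 1 to compound 3 (0.31 log units; beyond the scatter), as no pair differing in one place joins that step to this one.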